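A few compounds are considered here, and "the series" means these few. Any claim that something is new, unique, unknown or untested is made for them only; others in the source may bear on it.

Measured compounds:
compound 1 `COc1ccc(-c2c(S(=O)(=O)c3ccc(F)c(F)c3)cnc3cc(F)ccc23)cc1` with 1.1 mL/min
compound 2 `COc1ccc(-c2c(S(=O)(=O)c3cc(F)cc(F)c3)cnc3cc(F)ccc23)cc1` with 1.51 mL/min
compound 3 `COc1cccc(-c2c(S(=O)(=O)c3cccc(C#N)c3)cnc3cc(F)ccc23)c1` with 1.83 mL/min

In an ADME assay on microsomes from liver (Homo sapiens) for metabolic stability, tested at 2.5 uM (on this read-out lower numbers stand for slow clearance and higher numbers for fast clearance), compound 3 gives the highest of the three numbers, yet its gaps to compound 2 and to compound 1 both lie within the scatter of repeated measurements, so the three compounds sit in the same band. Compound 4 `COc1ccc(-c2c(S(=O)(=O)c3cccc(C#N)c3)cnc3cc(F)ccc23)cc1` is not yet measured. It differs from compound 3 in one place: 4-methoxyphenyl in place of 3-methoxyphenyl on an aromatic carbon.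

Going by the values given here, only one measured step exists, a 1.4-fold higher number from compound 1 to compound 2 (0.14 log units; within the scatter), and it concerns the group on the sulfonyl sulfur, not the methoxyphenyl, so it bears only indirectly on this change. Among the compounds with values here, no measured step moves the methoxy group from one position to the other. Compounds 1 and 2 both carry 4-methoxyphenyl and their values are within the scatter of compound 3, which carries 3-methoxyphenyl. The expected step is therefore none beyond the scatter, a 1.2-fold lower number from compound 3 to compound 4 (0.09 log units; within the scatter). Compound 4 is estimated at 1.5 mL/min, within a range from 0.75 mL/min to 3 mL/min in this assay.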

Compound 4, intrinsic clearance in a liver preparation (reported as CLH), per the amount of preparation that the assay uses: 0.92 mL/min
Compound 4: middle estimate off by 1.6-fold (0.21 log units), on the high side; the measured number falls inside the stated range.
By their numbers in this assay, from the lowest: compounds 4, 1, 2 and 3 (each within the scatter of the next).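

In this assay, the move of the methoxy group now has a direct reading: 4-methoxyphenyl in place of 3-methoxyphenyl gives a 2.0-fold lower number from compound 3 to compound 4 (0.30 log units; within the scatter), so this change on an aromatic carbon does not separate the pair beyond the scatter. With 4-methoxyphenyl held constant, 3-cyanophenyl in place of 3,5-difluorophenyl on the sulfonyl sulfur gives a 1.6-fold lower number from compound 2 to compound 4 (0.22 log units; within the scatter), and 3-cyanophenyl in place of 3,4-difluorophenyl gives a 1.2-fold lower number from compound 1 to compound 4 (0.08 log units; within the scatter), and both steps also stay within the scatter. Nothing measured here offers an explanation for these numbers.

The compounds shown leave open whether the same methoxy move would read alike with either difluorophenyl group on the sulfonyl sulfur. They also leave open whether an amine, a carboxylic acid or an ethoxy group at this position would give a step beyond the scatter.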